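A few compounds are considered here, and "the series" means these few. Any claim that something is new, unique, unknown or untested is made for them only; others in the source may bear on it.

Series notes. The shared core is carried by compound 1 `CC(=O)Nc1cccc(C2CCN(CCCn3c(-c4cccc(C(F)(F)F)c4)nc4ccccc43)CC2)c1`, compound 2 `CC(=O)Nc1cccc(C2CCN(CCCn3c(-c4ccc(Br)cc4)nc4ccccc43)CC2)c1` and compound 3 `CC(=O)Nc1cccc(C2CCN(CCCn3c(-c4ccc(Cl)c(Cl)c4)nc4ccccc43)CC2)c1`, which differ only in the aryl group attached to it. In an assay for displacement of a labelled ligand from melanin-concentrating hormone receptor 1 (Homo sapiens), read by fluorescence (a higher number here means a weaker inhibitor, a lower number a stronger inhibitor), compound 1 gives 30 nM, compound 2 gives 5 nM and compound 3 gives 24 nM. Compound 3 stands second highest of the three numbers; the smallest gap to it is a 1.3-fold lower number from compound 1 to compound 3 (0.10 log units; within the scatter) and the largest is a 4.8-fold higher number from compound 2 to compound 3 (0.68 log units; beyond the scatter).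

Compound 4 `CC(=O)Nc1cccc(C2CCN(CCCn3c(-c4ccc(F)c(F)c4)nc4ccccc43)CC2)c1` follows from compound 3 by the change (3,4-difluorophenyl in place of 3,4-dichlorophenyl on an aromatic carbon). Among the compounds with values here, no measured step exchanges one halogen for another while keeping the substitution pattern; the steps that touch this aryl group are a 6.0-fold lower number from compound 1 to compound 2 (0.78 log units; beyond the scatter), a 1.3-fold lower number from compound 1 to compound 3 (0.10 log units; within the scatter) and a 4.8-fold higher number from compound 2 to compound 3 (0.68 log units; beyond the scatter), each of which changes the pattern as well as the atoms. Together they show that the aryl group moves this assay by modest amounts at most, and nothing in them points to a direction for a pure halogen swap. For compound 4 the expected step is therefore a 1.5-fold higher number from compound 3 to compound 4 (0.16 log units; within the scatter), within the scatter or close to it. The estimate for compound 4 in this assay is 35 nM, with a range from 12 nM to 100 nM.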

Compound 4, half-maximal inhibitory concentration: 4 nM
The estimate for compound 4 lay 8.8-fold (0.94 log units) above the measured number, outside the stated range (below it).
By their numbers in this assay, from the lowest: compounds 4 and 2 (each within the scatter of the next); then compounds 3 and 1 (each within the scatter of the next).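

Within this assay, the identity of the halogen matters on its own at this aromatic carbon between two ring nitrogen atoms: with the substitution pattern held, the exchange of 3,4-dichlorophenyl for 3,4-difluorophenyl gives a 6.0-fold lower number from compound 3 to compound 4 (0.78 log units; beyond the scatter), a separation that the earlier steps could not show, since each of them changed the pattern as well as the atoms. The 3,4-difluorophenyl group also gives a 7.5-fold lower number from compound 1 to compound 4 (0.88 log units; beyond the scatter), while the comparison with 4-bromophenyl gives a 1.3-fold lower number from compound 2 to compound 4 (0.10 log units; within the scatter), so two aryl groups with different patterns now sit level at the low end, and compound 3 stands against any reading that the 3,4-pattern alone sets a low number. Nothing measured here gives a reason for the gap between the two dihalophenyl groups.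

The compounds shown leave open how an unsubstituted phenyl ring would compare with these halogenated rings, and whether an amine or a carboxylic acid on this ring would be tolerated. Also open, going by these compounds, is whether the halogen effect would persist with a longer chain in place of the propyl linker of the shared core.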